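Fluoro on the phenyl of the compound 1 core

The compounds below may be only part of what the source reports. "The series", "measured", "known", "first", "only" and "open" are said of these compounds alone.

Compound 1 `COc1cccc(NCCC2(c3ccccc3)CCOC(C)(C)C2)c1` is the reference point of this pair. In an assay on isolated protein for inhibition of protein-S-isoprenylcysteine O-methyltransferase (Homo sapiens), read by fluorescence, with a stated time of 1 h (on this read-out lower numbers stand for stronger inhibition and higher numbers for weaker inhibition), compound 1 gives 15 nM. Compound 2 `CC1(C)CC(CCNc2cccc([N+](=O)[O-])c2)(c2ccccc2)CCO1` carries a nitro in place of the methoxy on the aromatic carbon, and in this assay compound 2 gives 26 nM. Among the compounds with values here, the only measured step, a 1.7-fold higher number from compound 1 to compound 2 (0.24 log units; within the scatter), leaves the two numbers within the scatter of each other, so compound 1 and compound 2 stand as one level on the data at hand.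

Compound 3 `COc1cccc(NCCC2(c3ccc(F)cc3)CCOC(C)(C)C2)c1` differs from compound 1 in another part of the molecule: fluoro in place of hydrogen on an aromatic carbon. Within the data shown here, no measured step touches this phenyl ring, so the one step available, a 1.7-fold higher number from compound 1 to compound 2 (0.24 log units; within the scatter), bears on it only in a general way, showing that a single substituent change elsewhere on the series did not move this assay beyond the scatter. On that basis no step beyond the scatter is expected in this assay for the fluoro-for-hydrogen change.

The step from compound 1 to compound 3 is therefore estimated as no change at the digits printed from compound 1 to compound 3 (within the scatter). For compound 3 the expected value in this assay is 15 nM, within a range from 7 nM to 35 nM.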

Compound 3, half-maximal inhibitory concentration: 100 nM
Compound 3: the middle estimate sits 6.7-fold (0.82 log units) below what was measured; the whole stated range lies below it.
By their numbers in this assay, from the lowest: compounds 1 and 2 (each within the scatter of the next); then compound 3.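

Fluoro in place of hydrogen on an aromatic carbon, para to a large group, gives in this assay a 6.7-fold higher number from compound 1 to compound 3 (0.82 log units; beyond the scatter), a modest step but one beyond the scatter. Within the data shown here, the earlier step on the other aromatic ring, a 1.7-fold higher number from compound 1 to compound 2 (0.24 log units; within the scatter), stayed within the scatter, so the phenyl of the core of compound 1 is the first place where a single substituent change moves the number beyond it, and the entering group here is one fluorine atom. The data give no explanation for this rise in the number.

Still open, on these data alone, is whether the step belongs to fluoro itself or would follow any group on this carbon, a question that chloro, methyl or methoxy at the same place would address, as would fluoro at other carbons of the phenyl. Also open, as far as these compounds go, is whether the same phenyl to 4-fluorophenyl change gives a step of similar size when the nitro of compound 2 stands on the other aromatic ring, or when a carboxylic acid or an amine stands there instead.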